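Compound 3 to compound 4: a new nitrogen substituent

This account rests on a few compounds, and the source may have more. Where it says the series, first, only, none or still open, it means among the compounds named here.

Measured in a functional assay on DU-145 cells (Homo sapiens) for cytotoxicity, read by trypan blue exclusion, with a stated time of 96 h (a lower number here means a stronger inhibitor, a higher number a weaker inhibitor), so far
- compound 1 `COc1cc(OC)c(/C=C/S(=O)(=O)Cc2ccc(OC)cc2[N+](=O)[O-])c(OC)c1` gives 20000 nM
- compound 2 `COc1ccc(CS(=O)(=O)/C=C/c2c(OC)cc(OC)cc2OC)c(N)c1` gives 25 nM
- compound 3 `COC(=O)C(Nc1cc(CS(=O)(=O)/C=C/c2c(OC)cc(OC)cc2OC)ccc1OC)c1ccccc1` gives 75 nM

Compound 3 is second highest of the three, above compound 2 and far below compound 1. Next is compound 4 `COc1cc(OC)c(/C=C/S(=O)(=O)Cc2ccc(OC)c(NC(C)(C)C(=O)O)c2)c(OC)c1`, reached by 1-carboxy-1-methylethyl in place of methoxycarbonyl)(benzyl on a nitrogen on an aromatic ring on a nitrogen on an aromatic ring. For the measured compounds named here, the only measured step, an 800-fold lower number from compound 1 to compound 2 (2.90 log units; beyond the scatter), is large, but it swaps nitro for amino and does not touch this substituent, so it sets no size here. Compound 2 and compound 3 lie much closer together, though beyond the scatter. No step beyond the scatter is therefore expected in this assay, and the estimated change is a 1.3-fold higher number from compound 3 to compound 4 (0.12 log units; within the scatter) in this reading. The estimate for compound 4 is 100 nM, with an expected range of 25 nM to 600 nM in all.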

Compound 4, half-maximal inhibitory concentration: 150 nM
Compound 4: the middle estimate sits 1.5-fold (0.18 log units) below what was measured; the measured number falls inside the stated range.
By their numbers in this assay, from the lowest: compound 2; then compounds 3 and 4 (each within the scatter of the next); then compound 1.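

In this assay, the substituent on this nitrogen on an aromatic ring can change substantially without a step beyond the scatter: 1-carboxy-1-methylethyl in place of methoxycarbonyl)(benzyl gives a 2.0-fold higher number from compound 3 to compound 4 (0.30 log units; within the scatter). The six-membered aromatic ring of the leaving group is therefore not required to stay within the scatter here, and a free carboxy group is accepted. No evidence on hand explains this outcome.

With the ring and the ester changing together, their separate contributions remain unresolved. An amide on this nitrogen, or a longer chain ending in a carboxylic acid, would test how far this holds.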